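A few compounds are considered here, and "the series" means these few. Any claim that something is new, unique, unknown or untested is made for them only; others in the source may bear on it.

Measured so far:
compound 1 `COc1cccc(/C=N/NC(=O)c2cccnc2Nc2cccc(C(F)(F)F)c2)c1` gives 49.7% in a functional assay on the whole organism (strain Wistar) for inhibition, with Rattus norvegicus as the target, read by paw edema, with a stated time of 2 h, at a dose of 10 mg/kg by the intraperitoneal route; a lower number here means less inhibition, a higher number more inhibition at the dose given (going by the name of the read-out).
Compound 2 `COc1ccc(/C=N/NC(=O)c2cccnc2Nc2cccc(C(F)(F)F)c2)cc1` gives 42.4%.
Compound 3 `O=C(N/N=C/c1cccnc1)c1cccnc1Nc1cccc(C(F)(F)F)c1` gives 62.4%.

Compound 3 stands highest of the three numbers, and both steps leading to it, a number 12.7 percentage points higher from compound 1 to compound 3 (beyond the scatter) and a number 20 percentage points higher from compound 2 to compound 3 (beyond the scatter), lie beyond the scatter. Compound 4 `O=C(N/N=C/c1ccncc1)c1cccnc1Nc1cccc(C(F)(F)F)c1` differs from compound 3 in one place: pyridin-4-yl in place of pyridin-3-yl on a carbon with a double bond to nitrogen. Going by the values given here, no measured step moves a ring nitrogen, but the nearest comparison is the shift of the methoxy group, a number 7.3 percentage points lower from compound 1 to compound 2 (within the scatter), which stayed within the scatter. On that basis the writer expects the step of a number 5.4 percentage points lower from compound 3 to compound 4 (within the scatter) to stay within the scatter, with a slight lean downward. Compound 4 is therefore estimated at 57%, within a range from 42% to 70%.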

Compound 4, a percentage reported as inhibition, in the whole organism at one dose (the size of the read-out at that dose, not a potency): 65.2%
For compound 4 the middle estimate is 8.2 percentage points below the measured one; low and high end bracket the measured number.
By their numbers in this assay, from the lowest: compounds 2 and 1 (each within the scatter of the next); then compounds 3 and 4 (each within the scatter of the next).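

In this assay, pyridin-4-yl in place of pyridin-3-yl on the carbon with a double bond to nitrogen gives a number 2.8 percentage points higher from compound 3 to compound 4 (within the scatter) and so the two pyridines cannot be told apart at this position. The second pyridine also stands clear of both methoxyphenyl compounds, with a number 22.8 percentage points higher from compound 2 to compound 4 (beyond the scatter) and a number 15.5 percentage points higher from compound 1 to compound 4 (beyond the scatter) so the advantage seen for compound 3 is not confined to pyridin-3-yl. Nothing available explains the difference between the pyridines and the methoxyphenyl groups. The compounds shown leave open whether pyridin-2-yl would match the other two pyridines at this place, and how an unsubstituted phenyl or a piperidin-4-yl would compare.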